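A few compounds are considered here, and "the series" means these few. Any claim that something is new, unique, unknown or untested is made for them only; others in the source may bear on it.

Three compounds have been measured in a functional assay on CHO cells for inhibition of metabotropic glutamate receptor 5 (Rattus norvegicus), read by FLIPR and calcium flux; a lower number here means a stronger inhibitor, a higher number a weaker inhibitor:

Compound 1 `Cc1ccc2ccc(-c3cc(Cl)cc(C#N)c3)cc2n1` gives 1.4 nM.
Compound 2 `Cc1ccc2ccc(-c3cc(Br)cc(C#N)c3)cc2n1` gives 13 nM.
Compound 3 `Cc1ccc2ccc(-c3cc(C#N)cc(OC(C)C)c3)cc2n1` gives 310 nM.

Compound 3 stands at the weak end of this small set: the step of a 220-fold higher number from compound 1 to compound 3 (2.35 log units; beyond the scatter) and the step of a 24-fold higher number from compound 2 to compound 3 (1.38 log units; beyond the scatter) are both beyond the scatter, so the isopropoxy compound is clearly the weakest of the three in this assay.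

Compound 4 `Cc1ccc2ccc(-c3cc(O)cc(C#N)c3)cc2n1` differs from compound 3 in one place: hydrogen in place of isopropyl on an oxygen on an aromatic ring. Going by the values given here, none of the measured steps concerns this exact change; they only show that swapping chloro for bromo gives a 9.3-fold higher number from compound 1 to compound 2 (0.97 log units; beyond the scatter), and that replacing either halogen by isopropoxy costs a great deal. Among the compounds with values here, the isopropyl portion is removed here, but no measured pair says whether a bare hydroxy recovers potency or loses more. The expectation is therefore a modest move, wide in uncertainty, with compound 4 expected to show a 1.9-fold higher number from compound 3 to compound 4 (0.29 log units; within the scatter) in this assay.

Compound 4 is estimated at 600 nM, with a range from 100 nM to 4000 nM.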

Compound 4, half-maximal inhibitory concentration: 360 nM
The estimate for compound 4 lay 1.7-fold (0.22 log units) above the measured number, and the stated range covers the measured number.
By their numbers in this assay, from the lowest: compound 1; then compound 2; then compounds 3 and 4 (each within the scatter of the next).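

In this assay, taking the isopropyl off the oxygen changes nothing that can be told from the scatter, with a 1.2-fold higher number from compound 3 to compound 4 (0.06 log units; within the scatter), so at this place on the ring removing that chain recovers none of the potency seen with the halogens. The hydroxy compound stays far from both halogen compounds, with a 28-fold higher number from compound 2 to compound 4 (1.44 log units; beyond the scatter) and a 260-fold higher number from compound 1 to compound 4 (2.41 log units; beyond the scatter), so among the four compounds the two groups joined through oxygen both sit at the weak end, not just the larger one. No available evidence explains why these two groups read alike.

Still open, going by these compounds, is how a methoxy group or an amine would read at this place, and so whether the oxygen link itself goes with the weak numbers. On these data alone, whether fluoro would match chloro also remains unknown.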